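The source may report more compounds than this note shows. Statements on the series, on what has been measured and on what is new or still open speak of the compounds shown alone.

Measured to date in a toxicity assay on HepG2 cells (Homo sapiens) for inhibition, read by CellTiter-Glo, with a stated time of 48 h; a higher number here means a weaker inhibitor, a lower number a stronger inhibitor:

- compound 1 `CSc1ccc2nc(C)cc(OCC(=O)Nc3cc(C)cc(C)c3)c2c1` gives > 100000 nM, which is a limit of the assay and not a number.
- compound 2 `Cc1cc(C)cc(NC(=O)COc2cc(C)nc3ccc(Cl)cc23)c1` gives > 100000 nM, likewise a limit of the assay.
- compound 3 `COc1cc2nc(C)cc(OCC(=O)Nc3cc(C)cc(C)c3)c2cc1OC` gives 10000 nM.

Compound 2 therefore stands at the limit, with no number of its own. Two of the three values shown sit there (the limit of > 100000 nM in this assay, at which 2 of the 3 values shown sit). Among the compounds with values here, the single step between measured neighbours, the change from compound 1 to compound 2 a step that the two limits leave unreadable from compound 1 to compound 2, cannot be read for size. Both of its ends are limits. Within the data shown here, compound 3, carrying two methoxy groups on the shared core, is the only member with a real number in this assay, and it is a weak one.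

The next compound to be measured is compound 4 `Cc1cc(C)cc(NC(=O)COc2cc(C)nc3ccc(OCc4ccccc4)cc23)c1`. Relative to compound 2 the change is benzyloxy in place of chloro on an aromatic carbon. Among the measured compounds shown here, no measured step covers a benzyloxy group at this place, and the one step available gives no usable size. Compound 3 shows only that an oxygen-linked substituent on this ring can bring a value into the readable window. Compound 4 is accordingly expected to sit at or near the limit in this assay, with an estimate of 60000 nM and a range from 15000 nM to 200000 nM. The expected step is an at least 1.6-fold lower number from compound 2 to compound 4 (0.22 log units; that floor lies within the scatter).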

Compound 4, half-maximal inhibitory concentration: > 100000 nM
Compound 4: only a limit was reported (the forecaster's own chance of this, stated with the estimate: 55%); at least 1.6-fold (0.22 log units) between middle value and limit.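

In this assay compound 4 gives > 100000 nM, a limit of the assay and not a number. The steps to compound 4 from compound 2 and from compound 1 cannot be read for size, with all three compounds at the same limit: the limit of > 100000 nM in this assay, at which 3 of the 4 values shown sit.

The compounds shown leave open how methylsulfanyl, chloro and benzyloxy at this place on the shared core compare, none of the three carrying a number of its own.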